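Replacing the piperidine ring on a coumarin amide side chain

The source may report more compounds than this note shows. Statements on the series, on what has been measured and on what is new or still open speak of the compounds shown alone.

Compound 1, `CC(C)=CCc1cc(C(=O)Nc2cc3ccc(OCCC4CCCCN4)c(C)c3oc2=O)ccc1O`: in a functional assay on MCF7 cells (Homo sapiens) for antiproliferative activity (a higher number here means a weaker inhibitor, a lower number a stronger inhibitor), compound 1 gives 710 nM.
Compound 2, `CC(C)=CCc1cc(C(=O)Nc2cc3ccc(OCCCNCC(C)C)c(C)c3oc2=O)ccc1O`: in this assay compound 2 gives 1320 nM.
Compound 3, `CC(C)=CCc1cc(C(=O)Nc2cc3ccc(OCCCNC(C)(C)C)c(C)c3oc2=O)ccc1O`: in this assay compound 3 gives 950 nM.

Compound 1 holds the lowest of the three numbers, yet neither step away from it clears the scatter: a 1.3-fold higher number from compound 1 to compound 3 (0.13 log units; within the scatter) and a 1.9-fold higher number from compound 1 to compound 2 (0.27 log units; within the scatter). Between the two acyclic amines the picture is the same, a 1.4-fold lower number from compound 2 to compound 3 (0.14 log units; within the scatter).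

Compound 4, `CC(C)=CCc1cc(C(=O)Nc2cc3ccc(OCCCNCCO)c(C)c3oc2=O)ccc1O`, has not yet been measured in this assay. It differs from compound 1 in one place: ((2-hydroxyethyl)amino)methyl in place of piperidin-2-yl on a saturated chain carbon, two bonds along the chain from an oxygen on an aromatic ring. The two measured steps that exchange piperidin-2-yl for an acyclic amino group on the same chain carbon both stayed within the scatter, so no step beyond the scatter is expected here either. Compound 4 is therefore estimated at 1000 nM, with a range from 450 nM to 2500 nM, which would amount to a 1.4-fold higher number from compound 1 to compound 4 (0.15 log units; within the scatter).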

Compound 4, half-maximal inhibitory concentration: 1560 nM
Compound 4: middle estimate off by 1.6-fold (0.19 log units), on the low side; measured number inside the range.
By their numbers in this assay, from the lowest: compounds 1, 3, 2 and 4 (each within the scatter of the next, the first and the last beyond it).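

In this assay, for the compounds shown here, the change to ((2-hydroxyethyl)amino)methyl is the only exchange of piperidin-2-yl on this chain carbon that leaves the scatter, and only modestly: a 2.2-fold higher number from compound 1 to compound 4 (0.34 log units; beyond the scatter). It does not separate compound 4 from the other acyclic amines, since a 1.6-fold higher number from compound 3 to compound 4 (0.22 log units; within the scatter) and a 1.2-fold higher number from compound 2 to compound 4 (0.07 log units; within the scatter) both stay within the scatter. No measurement at hand offers a reason for the step away from the piperidine. Open, from the compounds shown here alone, is whether a morpholine or a pyrrolidine in the same place would stay level with compound 1 or match compound 4.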